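From methoxy to phenoxy on a shared core

This account rests on a few compounds, and the source may have more. Where it says the series, first, only, none or still open, it means among the compounds named here.

Measured in a functional assay on MIA PaCa-2 cells (Homo sapiens) for cytotoxicity, read by MTT assay, with a stated time of 72 h; on this read-out lower numbers stand for stronger inhibition and higher numbers for weaker inhibition:
compound 1 `O=C1C(Nc2ccc(OC(F)(F)F)cc2)=CC(=O)c2ncncc21` gives 1400 nM
compound 2 `COc1ccc(-c2ccc(NC3=CC(=O)c4ncncc4C3=O)cc2)cc1` gives 2100 nM
compound 3 `COc1ccc(NC2=CC(=O)c3ncncc3C2=O)cc1` gives 1900 nM

Compound 3 sits between the other two, and all three numbers lie within the scatter of one another, so no order among them can be read. Compound 4 `O=C1C(Nc2ccc(Oc3ccccc3)cc2)=CC(=O)c2ncncc21` differs from compound 3 by phenyl in place of methyl on an oxygen on an aromatic ring. For the measured compounds named here, two measured steps touch the same spot on the shared core: a 1.4-fold higher number from compound 1 to compound 3 (0.13 log units; within the scatter), and a 1.1-fold lower number from compound 2 to compound 3 (0.04 log units; within the scatter). Neither moved the number beyond the scatter, so for compound 4 a step of a 1.1-fold lower number from compound 3 to compound 4 (0.05 log units; within the scatter) is expected, with no change beyond the scatter. Compound 4 is therefore estimated at 1700 nM, within a range from 700 nM to 4200 nM.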

Compound 4, half-maximal inhibitory concentration: 3700 nM
Compound 4: middle estimate off by 2.2-fold (0.34 log units), on the low side; the measured number falls inside the stated range.
By their numbers in this assay, from the lowest: compounds 1, 3, 2 and 4 (each within the scatter of the next, the first and the last beyond it).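

Among these compounds, only the change from trifluoromethyl to phenyl on an oxygen on an aromatic ring gives a step beyond the scatter, and a modest one (a 2.6-fold higher number from compound 1 to compound 4 (0.42 log units; beyond the scatter)). The other two new steps (a 1.9-fold higher number from compound 3 to compound 4 (0.29 log units; within the scatter)) and (a 1.8-fold higher number from compound 2 to compound 4 (0.25 log units; within the scatter)) stay within the scatter, so phenoxy cannot be told apart from methoxy or 4-methoxyphenyl here. For the compounds shown here, nothing available explains the one larger step.

As far as these compounds go, it remains open how a longer chain, such as butyl, on this oxygen would read. From the compounds shown here alone, an amine or a carboxylic acid in place of these groups also remains open.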